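A few compounds are considered here, and "the series" means these few. Any claim that something is new, unique, unknown or untested is made for them only; others in the source may bear on it.

Measured compounds and their values:

Compound 1 `CCOC(=O)c1cn(CCCc2ccccc2)c2cc(Cl)ccc2c1=O` — 16100 nM
Compound 2 `CCCCn1cc(C(=O)OCC)c(=O)c2ccc(Cl)cc21` — 41700 nM
Compound 3 `CCOC(=O)c1cn(Cc2ccccc2)c2cc(Cl)ccc2c1=O` — 27900 nM

In a functional assay on PC-3 cells (Homo sapiens) for cytotoxicity, read by MTT assay, with a stated time of 24 h (a higher number here means a weaker inhibitor, a lower number a stronger inhibitor), compound 3 stands second highest of the three numbers. Its nearest neighbour is compound 2, reached by a 1.5-fold lower number from compound 2 to compound 3 (0.17 log units; within the scatter), and its furthest is compound 1, reached by a 1.7-fold higher number from compound 1 to compound 3 (0.24 log units; within the scatter); both of these steps lie within the scatter, so compound 3 cannot be placed in any order against either of them.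

Compound 4 `CCOC(=O)c1cn(CC)c2cc(Cl)ccc2c1=O` differs from compound 3 in one place: methyl in place of phenyl on a saturated chain carbon bound to an aromatic nitrogen. Going by the values given here, only one measured step involves a phenyl giving way to a methyl, namely a 2.6-fold higher number from compound 1 to compound 2 (0.41 log units; beyond the scatter), a modest rise in the number, though there the exchange sits three bonds along the chain from the aromatic nitrogen rather than on the carbon bound to it. The step of a 1.5-fold lower number from compound 2 to compound 3 (0.17 log units; within the scatter) concerns the same chain carbon but swaps propyl for phenyl and stays within the scatter. On that footing the step from compound 3 to compound 4 is expected to raise the number in this assay modestly, by about a 1.8-fold higher number from compound 3 to compound 4 (0.25 log units; within the scatter). Compound 4 is therefore estimated at 50000 nM in this assay, with a range from 20000 nM to 125000 nM.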

Compound 4, half-maximal inhibitory concentration: > 50000 nM
Compound 4 gave a limit, no number; the forecaster's own chance of this, stated with the estimate: 15%; the middle value sits exactly at the limit.
By their numbers in this assay, from the lowest: compounds 1, 3 and 2 (each within the scatter of the next, the first and the last beyond it). At a limit, above all of these: compound 4.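

In this assay compound 4 gives only a limit, > 50000 nM, not a number. Going by these compounds alone, the one step from it that can be read with confidence is an at least 3.1-fold higher number from compound 1 to compound 4 (0.49 log units; beyond the scatter), which clears the scatter and shows that hydrogen in place of benzyl on a saturated chain carbon, two bonds along the chain from an aromatic nitrogen, costs activity. The floors of the other two steps, an at least 1.7-fold higher number from compound 3 to compound 4 (0.25 log units; that floor lies within the scatter) and an at least 1.1-fold higher number from compound 2 to compound 4 (0.07 log units; that floor lies within the scatter), lie within the scatter, so neither step can be read as a real change, and methyl in place of phenyl, now seen at two places on the chain, cannot yet be said to act alike at both: the same change on two cores in this assay, a 2.6-fold higher number (0.41 log units; beyond the scatter) from compound 1 to compound 2 and an at least 1.7-fold higher number (0.25 log units; that floor lies within the scatter) from compound 3 to compound 4; the limit leaves it open whether they differ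

Going by these compounds, how far compound 4 lies beyond its limit stays open, and with it the true size of each of these steps. Also open, on these data alone, is whether a longer chain carrying the phenyl, or an amine or a carboxylic acid at the end of the chain in its place, would move the number in this assay.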